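Chain-extended isothiocyanate analogues on a shared pyrrolopyrimidine-amide core

The compounds below may be only part of what the source reports. "The series", "measured", "known", "first", "only" and "open" are said of these compounds alone.

Measured compounds:
compound 1 `CN(C)C(=O)c1cc2cnc(Nc3ccc(C(=O)NCCCCCCN=C=S)cc3)nc2n1C1CCCC1`: 100%
compound 2 `CN(C)C(=O)c1cc2cnc(Nc3ccc(C(=O)NCCCCCCCN=C=S)cc3)nc2n1C1CCCC1`: 101%
compound 3 `CN(C)C(=O)c1cc2cnc(Nc3ccc(NC(=O)CCCN=C=S)cc3)nc2n1C1CCCC1`: 102%

In a functional assay on A549 cells (Homo sapiens) for inhibition, read by CCK-8 assay, with a stated time of 72 h, tested at 10 uM (a lower number here means a weaker effect, a higher number a stronger effect of the compound at the concentration tested), compound 1 gives 100%, compound 2 gives 101% and compound 3 gives 102%; all three sit at the top of the read-out. Compound 2 differs from compound 1 by a group of 4 heavy atoms (2 carbon, 1 nitrogen, 1 sulfur; no ring) in place of a group of 3 heavy atoms (1 carbon, 1 nitrogen, 1 sulfur; no ring), on a saturated chain carbon, six bonds along the chain from an amide-type nitrogen, and that step is a number 1 percentage points higher from compound 1 to compound 2 (within the scatter). Compound 3 differs from compound 1 by a group of 9 heavy atoms (5 carbon, 2 nitrogen, 1 oxygen, 1 sulfur; no ring) in place of a group of 12 heavy atoms (8 carbon, 2 nitrogen, 1 oxygen, 1 sulfur; no ring), on an aromatic carbon, and that step is a number 2 percentage points higher from compound 1 to compound 3 (within the scatter).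

Compound 4 `CN(C)C(=O)c1cc2cnc(Nc3ccc(NC(=O)CCCCN=C=S)cc3)nc2n1C1CCCC1` has not been measured. It differs from compound 3 by a group of 4 heavy atoms (2 carbon, 1 nitrogen, 1 sulfur; no ring) in place of a group of 3 heavy atoms (1 carbon, 1 nitrogen, 1 sulfur; no ring), on a saturated chain carbon, three bonds along the chain from a carbonyl carbon, the same kind of change as from compound 1 to compound 2, though there the group sits six bonds along the chain from an amide-type nitrogen and here three bonds along the chain from a carbonyl carbon. Because a number 1 percentage points higher from compound 1 to compound 2 (within the scatter) lay within the scatter, the step from compound 3 to compound 4 is expected to be a number 1 percentage points lower from compound 3 to compound 4 (within the scatter). Compound 4 is therefore estimated at 101% in this assay, between 95% and 105%.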

Compound 4, a percentage reported as inhibition, at one concentration (the size of the read-out at that concentration, not a potency): 102%
Beside the measured number, compound 4's estimate is 1 percentage points below it; the measured number falls inside the stated range.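

In this assay the change from the group of 3 heavy atoms to the group of 4 heavy atoms gives no change at the digits printed from compound 3 to compound 4 (within the scatter), and the larger replacement on an aromatic carbon gives a number 2 percentage points higher from compound 1 to compound 4 (within the scatter). Set beside the earlier step, the same change carries from one core to the other with no difference that can be told apart: the same change on two cores in this assay, a number 1 percentage points higher (within the scatter) from compound 1 to compound 2 and no change at the digits printed (within the scatter) from compound 3 to compound 4, 1 percentage points apart, within the scatter of two such steps This shows only that the change leaves the read-out at its top on both cores; it does not show that the two cores respond alike at lower concentrations, where a difference might appear.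

The compounds shown leave open how the series reads with an amine or a carboxylic acid at the chain end in place of the isothiocyanate. They also leave open whether a much longer chain stays at the top of the read-out.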